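Cytotoxicity of two imidazole anilines and a bromobenzyl analogue

The compounds below may be only part of what the source reports. "The series", "measured", "known", "first", "only" and "open" are said of these compounds alone.

Compound 1 `COC(=O)c1ccc(NCc2cncn2Cc2ccc(N)cc2)cc1-c1ccccc1`: > 10000 nM
Compound 2 `Cc1ccccc1-c1cc(NCc2cncn2Cc2ccc(-c3ccccc3)cc2)ccc1-c1nc2ccccc2s1`: > 1000 nM

In a toxicity assay on NIH3T3 cells (Mus musculus) for cytotoxicity, read by resazurin assay (a lower number here means that less compound is needed, a higher number that more compound is needed for the effect), compound 1 gives > 10000 nM, and this is a limit of the assay rather than a number. Compound 2 gives > 1000 nM in this assay, which is likewise a limit of the assay. Both compounds thus sit at limits: one value lies at the limit described by the limit of > 10000 nM in this assay, at which 1 of the 2 values shown sits, and the other at the limit described by the limit of > 1000 nM in this assay, at which 1 of the 2 values shown sits. Compound 1 therefore stands at the less stringent of the two, and no numeric position for it is known. Among the measured compounds shown here, no pair of measured compounds differs in a single place, so no measured step is available.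

Compound 3 `COC(=O)c1ccc(NCc2cncn2Cc2ccccc2Br)cc1-c1ccccc1` is not yet measured in this assay. It differs from compound 1 by 2-bromophenyl in place of 4-aminophenyl on a saturated chain carbon bound to an aromatic nitrogen. Since compound 1 gave only a limit, the step from compound 1 to compound 3 is expected to be small or absent, a number no higher from compound 1 to compound 3 (the limit leaves the size open), with a fair chance that compound 3 also gives only a limit. For compound 3 in this assay the expected value is 10000 nM, in the range 3000 nM to 30000 nM.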

Compound 3, half-maximal effective concentration: 10000 nM
Compound 3: middle estimate and measured number agree at the digits printed; measured number inside the range.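

In this assay compound 3 gives 10000 nM, the only actual number among the compounds shown, so with 2-bromophenyl on a saturated chain carbon bound to an aromatic nitrogen the series gains its first readable value. Compound 1 gives > 10000 nM, which is a limit of the assay and not a number. The change from 4-aminobenzyl to 2-bromobenzyl therefore stands only as a number no higher from compound 1 to compound 3 (the limit leaves the size open), and its size cannot be read because the value it starts from is a limit: the limit of > 10000 nM in this assay, at which 1 of the 3 values shown sits.

The change removes the amine and brings in the bromine in a single step, so the compounds shown cannot tell which of the two matters in this assay, and compound 2 differs from the others in more than one place and offers no help. As far as these compounds go, an unsubstituted benzyl group, or a chlorine in place of the bromine on the same benzyl group, would be needed to separate the two, and the shape of this position's effect on the cells stays open until then.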